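Ester in place of the ethylcarbamoyl group: lipophilicity notes

The source may hold more compounds than are shown below. What is called first, only, known or untested is meant among the compounds shown, and "the series" means these compounds.

Measured in a physicochemical assay for lipophilicity, read by HPLC, measured as octanol-water partition, with a stated time of 24 h, at pH 7.4; on this read-out lower numbers stand for lower lipophilicity and higher numbers for higher lipophilicity:
compound 1 `CCNC(=O)c1cc(N)c(Nc2ccc(C#N)cc2)cc1Oc1c(C)cc(CCC#N)cc1C` gives 3.63
compound 2 `Cc1cc(CCC#N)cc(C)c1Oc1cc(Nc2ccc(C#N)cc2)c(N)cc1CNC1CC1` gives 3.69

Going by the values given here, compound 1 holds the lower of the two numbers, but the only neighbour sits within the scatter: a number 0.06 log units higher from compound 1 to compound 2 (within the scatter). Compound 3 `Cc1cc(CCC#N)cc(C)c1Oc1cc(Nc2ccc(C#N)cc2)c(N)cc1COC(=O)C1CC1` is not yet measured; it differs from compound 1 by ((cyclopropylcarbonyl)oxy)methyl in place of ethylcarbamoyl on an aromatic carbon. Among the compounds with values here, the single step that bears on this position is the exchange from compound 1 to compound 2, which also replaced the ethylcarbamoyl group on the same aromatic carbon and left this assay essentially unchanged. Within the data shown here, no measured step covers an ester at this carbon, nor a change that removes the hydrogen-bond donor, so the expectation rests on the counted difference alone. Compound 3 is expected at 4.4, with a range from 3.8 to 5. This expected step, a number 0.77 log units higher from compound 1 to compound 3 (beyond the scatter), would be upward and beyond the scatter.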

Compound 3, partition coefficient: 2.51
The estimate for compound 3 lay 1.89 log units above the measured number, outside the stated range (below it).
By their numbers in this assay, from the lowest: compound 3; then compounds 1 and 2 (each within the scatter of the next).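

In this assay, this aromatic carbon no longer looks indifferent to the group it carries: the ((cyclopropylcarbonyl)oxy)methyl group gives a number 1.12 log units lower from compound 1 to compound 3 (beyond the scatter) and is thus set apart from the ethylcarbamoyl group, whereas the earlier exchange stayed within the scatter. A large downward step also appears on the saturated chain carbon bound to this aromatic carbon, with a number 1.18 log units lower from compound 2 to compound 3 (beyond the scatter) for (cyclopropylcarbonyl)oxy in place of cyclopropylamino, and the three-membered ring of carbon is present on both sides of that step. No supporting data are available to explain either step.

Open, on these data alone, is whether the lower number belongs to the ester link or to the whole group, which an acetate ester or a methoxymethyl group at this carbon would test. Also open, as far as these compounds go, is how a carboxylic acid or a longer ester chain would read here.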